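Adding One Methoxy Group to Compound 1

This account rests on a few compounds, and the source may have more. Where it says the series, first, only, none or still open, it means among the compounds named here.

- Compound 1 `O=C(NNC(=O)c1ccc2[nH]c(-c3ccc([N+](=O)[O-])o3)nc2c1)c1ccccc1`: 15.6 ug/mL
- Compound 2 `COc1cc(C(=O)NNC(=O)c2ccc3[nH]c(-c4ccc([N+](=O)[O-])s4)nc3c2)cc(OC)c1OC`: 62.5 ug/mL
- Compound 3 `COc1cccc(C(=O)NNC(=O)c2ccc3[nH]c(-c4ccc([N+](=O)[O-])o4)nc3c2)c1`: not yet measured

Among the compounds with values here, in a functional assay on M14 cells (Homo sapiens) for inhibition, read by sulforhodamine B assay, with a stated time of 48 h (on this read-out higher numbers stand for weaker inhibition of growth and lower numbers for stronger inhibition of growth), compound 1 gives 15.6 ug/mL, the lower of the two numbers so far and therefore the stronger inhibition of growth. Compound 2 gives 62.5 ug/mL, which is higher by more than the usual scatter. Compound 3 keeps the structure of compound 1 except at one place: methoxy in place of hydrogen on an aromatic carbon. This is methoxy in place of hydrogen on an aromatic carbon, turning phenyl into 3-methoxyphenyl.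

Within the data shown here, no measured pair isolates this change. Compound 2 also carries methoxy groups, but it differs from compound 1 elsewhere too, so compound 2 at 62.5 ug/mL is only a weak guide. With so little evidence, a single small substitution is expected to cause only a modest shift, towards a higher number if anything. The expected change is a 1.3-fold higher number from compound 1 to compound 3 (0.11 log units; within the scatter), with nothing beyond the scatter. For compound 3 the estimated value is 20 ug/mL, with an expected range of 7.8 ug/mL to 62.5 ug/mL.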

Compound 3, concentration for 50% growth inhibition: 7.81 ug/mL
Beside the measured number, compound 3's estimate is 2.6-fold (0.41 log units) above it; low and high end bracket the measured number.
By their numbers in this assay, from the lowest: compounds 3 and 1 (each within the scatter of the next); then compound 2.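

In this assay, within the data shown here, the pair of compound 1 and compound 3 is the first to isolate this change, and it gives a 2.0-fold lower number from compound 1 to compound 3 (0.30 log units; within the scatter). Turning phenyl into 3-methoxyphenyl therefore leaves growth inhibition indistinguishable from that of the parent, so this position accepts a methoxy group without a measurable loss, something compound 2 could not show since it differs from compound 1 in more than one place. Nothing available here bears on what lies behind this result.

Going by these compounds, it remains open whether this position would accept other groups equally well, such as an amine, a carboxylic acid or a longer chain. On these data alone, it is also open whether methoxy would give a similar result at other carbons of the same phenyl ring.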